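The source may report more compounds than this note shows. Statements on the series, on what has been measured and on what is new or still open speak of the compounds shown alone.

Measured so far:
Compound 1, `CCOC(=O)/C=C/c1ccncc1-c1ccc2ccccc2c1`, 8320 nM.
Compound 2, `O=C(O)/C=C/c1ccncc1-c1ccc2ccccc2c1`, > 10000 nM.
Compound 3, `CCOC(=O)/C=C/c1ccncc1-c1ccc2c(ccn2C)c1`, 8670 nM.

In a functional assay on MCF7 cells (Homo sapiens) for inhibition, read by sulforhodamine B assay, with a stated time of 72 h (a higher number here means a weaker inhibitor of growth, a lower number a stronger inhibitor of growth), compound 1 gives 8320 nM. For compound 2 the value > 10000 nM is a limit of the assay, not a number. The step from compound 1 to compound 2 is hydrogen in place of ethyl on an oxygen next to a carbonyl group, and it brought an at least 1.2-fold higher number from compound 1 to compound 2 (0.07 log units; that floor lies within the scatter); the reading rests on (the limit of > 10000 nM in this assay, at which 1 of the 3 values shown sits). Compound 3 gives 8670 nM, and it and compound 1 sit within the scatter of each other. The difference between the two cores of compound 1 and compound 3 is not broken down here.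

Compound 4, `Cn1ccc2cc(-c3cnccc3/C=C/C(=O)O)ccc21`, is not yet measured. It differs from compound 3 by hydrogen in place of ethyl on an oxygen next to a carbonyl group, the same change seen from compound 1 to compound 2. In this assay compound 4 is expected to show a 1.7-fold higher number from compound 3 to compound 4 (0.24 log units; within the scatter), resting on the earlier step of an at least 1.2-fold higher number from compound 1 to compound 2 (0.07 log units; that floor lies within the scatter). The expected value for compound 4 is 15000 nM. The expected range for compound 4 runs from 7000 nM to 40000 nM, with a fair chance that only a limit is reported.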

Compound 4, concentration for 50% growth inhibition: > 10000 nM
Compound 4: no number, only a limit; the forecaster's own chance of this, stated with the estimate: 65%; the middle value lies beyond the limit too.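

In this assay compound 4 gives > 10000 nM, which is a limit of the assay and not a number. The change from ethoxycarbonyl to carboxy brought an at least 1.1-fold higher number from compound 3 to compound 4 (0.06 log units; that floor lies within the scatter), and set beside the same change on the other core it reads: the same change on two cores in this assay, an at least 1.2-fold higher number (0.07 log units; that floor lies within the scatter) from compound 1 to compound 2 and an at least 1.1-fold higher number (0.06 log units; that floor lies within the scatter) from compound 3 to compound 4; the limit leaves it open whether they differ. On both cores, then, the carboxy compound ends up at the same limit, so the change brought no measurable gain in growth inhibition on either core, but this does not show that it costs the same on each, or that it costs anything at all: the limit of > 10000 nM in this assay, at which 2 of the 4 values shown sit.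

On these data alone, neither compound 2 nor compound 4 has a number, so the true size of this step on each core stays open. Also open, as far as these compounds go, is what an amide in place of the ester, or a chain longer than ethyl on the same oxygen, would do on either core.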